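A few compounds are considered here, and "the series" means these few. Any claim that something is new, unique, unknown or untested is made for them only; others in the source may bear on it.

In an ADME assay on HEL cells (Homo sapiens) for cytotoxicity, with a stated time of 3 days (a higher number here means that more compound is tolerated, a lower number that less compound is tolerated), three close relatives of one shared core have been measured. Compound 1, `Cc1cn([C@@H]2O[C@H](CO[Si](C)(C)C(C)(C)C(C)C)[C@@]3(OS(=O)(=O)C=C3NC(=O)NC(=O)c3ccccc3)[C@H]2O[Si](C)(C)C(C)(C)C)c(=O)n(C)c1=O`, reaches only the limit of the assay and gives > 50000 nM, which is a limit and not a number. Compound 2, `Cc1cn([C@@H]2O[C@H](CO[Si](C)(C)C(C)(C)C)[C@@]3(OS(=O)(=O)C=C3NC(=O)Nc3ccccc3)[C@H]2O[Si](C)(C)C(C)(C)C)c(=O)n(C)c1=O`, gives 1300 nM. Compound 3, `Cc1cn([C@@H]2O[C@H](CO[Si](C)(C)C(C)(C)C)[C@@]3(OS(=O)(=O)C=C3NC(=O)N(C(=O)Nc3ccccc3)c3ccccc3)[C@H]2O[Si](C)(C)C(C)(C)C)c(=O)n(C)c1=O`, gives 13000 nM. Among the two numbers shown, compound 2 stands as the lowest, and the single measured step that joins it to a neighbour is a 10-fold higher number from compound 2 to compound 3 (1.00 log units; beyond the scatter), a change on the same amide-type nitrogen that is altered again here.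

The unmeasured compound 4, `Cc1cn([C@@H]2O[C@H](CO[Si](C)(C)C(C)(C)C)[C@@]3(OS(=O)(=O)C=C3NC(N)=O)[C@H]2O[Si](C)(C)C(C)(C)C)c(=O)n(C)c1=O`, differs from compound 2 by hydrogen in place of phenyl on an amide-type nitrogen, so the anilino group becomes a plain amino group and the (phenylcarbamoyl)amino group becomes a ureido group. For the measured compounds named here, only the step to compound 3 bears on this nitrogen, and it went in the direction of more compound being tolerated when more was attached there; the present change attaches less, so no firm direction can be read from it, and a step of modest size at most is expected, most likely towards a higher number as compounds 1 and 3 both lie above compound 2. Compound 4 is therefore expected to give 4000 nM, within a range from 1000 nM to 30000 nM, which would mean an estimated step of a 3.1-fold higher number from compound 2 to compound 4 (0.49 log units; beyond the scatter).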

Compound 4, half-maximal cytotoxic concentration: 11000 nM
Beside the measured number, compound 4's estimate is 2.8-fold (0.44 log units) below it, and the stated range covers the measured number.
By their numbers in this assay, from the lowest: compound 2; then compounds 4 and 3 (each within the scatter of the next). At a limit, above all of these: compound 1.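

Taking the phenyl off this amide-type nitrogen, so that the (phenylcarbamoyl)amino group becomes a ureido group, gives an 8.5-fold higher number from compound 2 to compound 4 (0.93 log units; beyond the scatter). For the compounds shown here, until now the only measured change on this nitrogen was an addition, a 10-fold higher number from compound 2 to compound 3 (1.00 log units; beyond the scatter), so the new result shows that removing a group and adding one can both raise the number in this assay: compound 2, with the phenyl alone on the nitrogen, lies below both neighbours, while compound 4 and compound 3 sit within the scatter of each other. Nothing shown here explains why the tolerated concentration moves in both directions.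

A plain methyl or a cyclohexyl group in place of the phenyl would help to show whether the lower number in compound 2 goes with an aromatic ring of carbon only or with any carbon group on this nitrogen. A substituted phenyl, such as 4-chlorophenyl or 4-methoxyphenyl, would likewise test whether the number responds to changes on the ring itself, and the compounds shown leave both questions open.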